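Hydroxy added to a naphthalene-based lyase inhibitor

The source may report more compounds than this note shows. Statements on the series, on what has been measured and on what is new or still open speak of the compounds shown alone.

The study centres on compound 1 `Fc1ccc(-c2ccc3c(-c4cccnc4)cccc3c2)cc1`, which in an assay for inhibition of steroid 17-alpha-hydroxylase/17,20 lyase (Homo sapiens), tested at 2 uM (a lower number here means a weaker effect, a higher number a stronger effect of the compound at the concentration tested), gives 3%. Its companion, compound 2 `Fc1ccc(-c2ccc3c(-c4ccncc4)cccc3c2)cc1`, gives 28%, so that there is a number 25 percentage points higher from compound 1 to compound 2 (beyond the scatter). On the numbers shown, compound 1 therefore stands at the lower of the two values, with compound 2 the only neighbour and clearly apart from it.

The compound not yet measured, compound 3 `Oc1ccc2cc(-c3ccc(F)cc3)ccc2c1-c1cccnc1`, departs from compound 1 by a single change: hydroxy in place of hydrogen on an aromatic carbon. Among the compounds with values here, the one measured step between compound 1 and compound 2 concerns the exchange of one pyridyl group for another and says nothing about a hydroxy group entering the shared core, so no measured step bears on this change. With nothing in the data to argue for a rise or a fall, the step from compound 1 to compound 3 is expected to be small, a number 9 percentage points higher from compound 1 to compound 3 (within the scatter), and most likely to stay within the usual scatter. Compound 3 is accordingly estimated to give 12% in this assay, within a range from 0% to 40%.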

Compound 3, a percentage reported as inhibition, at one concentration (the size of the read-out at that concentration, not a potency): 0%
For compound 3 the middle estimate is 12 percentage points above the measured one; low and high end bracket the measured number.
By their numbers in this assay, from the lowest: compounds 3 and 1 (each within the scatter of the next); then compound 2.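

In this assay, hydroxy in place of hydrogen on the aromatic carbon ortho to the pyridin-3-yl group gives a number 3 percentage points lower from compound 1 to compound 3 (within the scatter), so this change on the shared core, unlike the exchange of one pyridyl group for another, has no effect that can be told from the scatter. Within the data shown here, compound 1 gives 3% and compound 3 gives 0%, both at the very bottom of the read-out at this concentration, so the result shows only that the hydroxy group brings no rise beyond the scatter here, while a loss of effect would have had almost no room to appear. Nothing available explains this result at the level of mechanism.

As far as these compounds go, it remains open whether the same hydroxy group would behave differently on the core of compound 2, which at 28% leaves room for a fall as well as a rise. From the compounds shown here alone, it is equally open what a methoxy group, an amine or a carboxylic acid would do at this position on the ring.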